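The compounds below may be only part of what the source reports. "The series", "measured", "known", "first", "only" and "open" are said of these compounds alone.

Measured compounds in a functional assay on MCF7 cells (Homo sapiens) for inhibition, read by MTT assay, with a stated time of 72 h; on this read-out higher numbers stand for weaker inhibition and lower numbers for stronger inhibition:
Compound 1 `O=C1Nc2ccc(F)cc2/C1=N/NC(=S)N1CCN(c2ccccc2)CC1` gives 24300 nM.
Compound 2 `O=C1Nc2ccc([N+](=O)[O-])cc2/C1=N/NC(=S)N1CCN(c2ccccc2)CC1` gives 23300 nM.
Compound 3 `COc1ccc(N2CCN(C(=S)N/N=C3\C(=O)Nc4ccc(Cl)cc43)CC2)cc1` gives 13800 nM.

Compound 3 holds the lowest of the three numbers, but both other compounds lie within the usual scatter of it, so no order among the three can be read. Compound 4 `O=C1Nc2ccc(Cl)cc2/C1=N/NC(=S)N1CCN(c2ccccc2F)CC1` differs from compound 3 by 2-fluorophenyl in place of 4-methoxyphenyl on an amine nitrogen in a ring. For the measured compounds named here, the only measured step, a 1.0-fold lower number from compound 1 to compound 2 (0.02 log units; within the scatter), concerns a substituent on the shared core rather than the ring on the amine nitrogen, and it stayed within the scatter. Going by the values given here, no measured step touches the changed ring, so nothing in these data points to a change beyond the scatter in this assay. Compound 4 is therefore expected to give 15000 nM, between 7000 nM and 32000 nM, a step of a 1.1-fold higher number from compound 3 to compound 4 (0.04 log units; within the scatter).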

Compound 4, half-maximal inhibitory concentration: 15200 nM
Compound 4: the middle estimate sits 1.0-fold (0.01 log units) below what was measured; measured number inside the range.
By their numbers in this assay, from the lowest: compounds 3, 4, 2 and 1 (each within the scatter of the next).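

In this assay, 2-fluorophenyl in place of 4-methoxyphenyl on an amine nitrogen in a ring gives a 1.1-fold higher number from compound 3 to compound 4 (0.04 log units; within the scatter). For the compounds shown here, this is the first measured change at this position, and it shows that these two groups can be exchanged there without a step beyond the scatter. Nothing measured here accounts for this result. The compounds shown leave open whether a carboxylic acid or an amine on this phenyl ring would move the number beyond the scatter. They also leave open what a cyclohexyl group in place of the ring would do.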